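Swapping the phenol ring for a pyrrole in compound 1

The compounds below may be only part of what the source reports. "The series", "measured", "known", "first", "only" and "open" are said of these compounds alone.

Compound 1 `CC1=CC[C@H](C(C)(C)NC(=S)N/N=C/c2ccc(O)cc2)CC1` carries a 4-hydroxyphenyl on the carbon that bears the double bond to nitrogen. In a functional assay on MCF7 cells (Homo sapiens) for inhibition, read by sulforhodamine B assay, with a stated time of 48 h (on this read-out lower numbers stand for stronger inhibition of growth and higher numbers for weaker inhibition of growth), compound 1 gives only a limit, > 100000 nM, so its true number is not known. Two changes to that ring have been measured. Compound 2 `CC1=CC[C@H](C(C)(C)NC(=S)N/N=C/c2ccc(N(C)C)cc2)CC1` gives 26800 nM in this assay, a step of an at least 3.7-fold lower number from compound 1 to compound 2 (0.57 log units; beyond the scatter). Compound 3 `COc1cc(/C=N/NC(=S)NC(C)(C)[C@H]2CC=C(C)CC2)ccc1O` gives 14800 nM, a step of an at least 6.7-fold lower number from compound 1 to compound 3 (0.82 log units; beyond the scatter). Both steps lowered the number, and both rest on the limit (the limit of > 100000 nM in this assay, at which 1 of the 3 values shown sits), so they set only a floor on their size.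

Compound 4 `CC1=CC[C@H](C(C)(C)NC(=S)N/N=C/c2ccc[nH]2)CC1` makes a different kind of change: 1H-pyrrol-2-yl in place of 4-hydroxyphenyl on a carbon with a double bond to nitrogen. Neither measured step replaces the whole ring, so they bear on it only loosely. On that basis compound 4 is expected to show a step of an at least 1.6-fold lower number from compound 1 to compound 4 (0.22 log units; that floor lies within the scatter) in this assay. The estimated value for compound 4 is 60000 nM, with a range from 15000 nM to 250000 nM, and a real chance that only a limit is again reported.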

Compound 4, concentration for 50% growth inhibition: 3900 nM
Estimate against measurement, compound 4: 15-fold (1.19 log units) above, and the stated range ends above it.
By their numbers in this assay, from the lowest: compound 4; then compounds 3 and 2 (each within the scatter of the next). At a limit, above all of these: compound 1.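

Compound 4 shows that the six-membered ring of compound 1 can be given up entirely on this carbon without loss of growth inhibition in this assay, with an at least 25-fold lower number from compound 1 to compound 4 (1.40 log units; beyond the scatter). Compound 2 and compound 3 both keep the six-membered ring, with compound 2 at 26800 nM and compound 3 at 14800 nM, while compound 4, with its five-membered ring, gives the lower number of 3900 nM. The value of compound 1 is a limit, so the step from it gives only a floor on the size of the change: the limit of > 100000 nM in this assay, at which 1 of the 4 values shown sits.

The compounds shown leave open whether the ring nitrogen with its hydrogen matters or only the five-membered ring, and a furan or a thiophene on this carbon would separate the two. They also do not tell why the number fell.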